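This account rests on a few compounds, and the source may have more. Where it says the series, first, only, none or still open, it means among the compounds named here.

Compound 2 `COc1cc(NC(C)CCCNC(=O)Nc2ccc(C(F)(F)F)cc2)c2ncccc2c1` gives 8300 nM in a functional assay on HeLa cells (Homo sapiens) for inhibition, read by MTT assay, with a stated time of 72 h (on this read-out higher numbers stand for weaker inhibition and lower numbers for stronger inhibition), the lower of the two numbers recorded, with compound 1 `COc1cc(NC(C)CCCNC(=O)Nc2ccc(F)cc2)c2ncccc2c1` giving 20000 nM. For the measured compounds named here, that one step, a 2.4-fold lower number from compound 1 to compound 2 (0.38 log units; beyond the scatter), is the only measured comparison, and it concerns a change of substituent on an aromatic ring rather than an exchange of the whole aryl group. Compound 3 `COc1cc(NC(C)CCCNC(=O)NNC(=O)Nc2cccc(Cl)c2)c2ncccc2c1` differs from compound 2 by ((3-chlorophenyl)carbamoyl)amino in place of 4-(trifluoromethyl)phenyl on an amide-type nitrogen. Going by the values given here, no recorded step bears on this kind of change, so the estimate for compound 3 stays close to compound 2 and is expected to be a 1.2-fold higher number from compound 2 to compound 3 (0.08 log units; within the scatter). Compound 3 is therefore estimated at 10000 nM, within a range of 3000 nM to 40000 nM.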

Compound 3, half-maximal inhibitory concentration: 44000 nM
The estimate for compound 3 lay 4.4-fold (0.64 log units) below the measured number, outside the stated range (above it).
By their numbers in this assay, from the lowest: compound 2; then compound 1; then compound 3.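

In this assay, putting ((3-chlorophenyl)carbamoyl)amino on the amide-type nitrogen gives a 5.3-fold higher number from compound 2 to compound 3 (0.72 log units; beyond the scatter) and a 2.2-fold higher number from compound 1 to compound 3 (0.34 log units; beyond the scatter). This exchange of the whole aryl group therefore weakens inhibition relative to both earlier compounds, with each step beyond the scatter. Nothing available explains this loss. The compounds shown leave open whether the change in the read-out follows from the carbamoylamino link or from the chlorophenyl ring it carries, and how a plain amine or a carboxylic acid on this nitrogen would read.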